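Inverting one stereocentre in compound 2

The source may hold more compounds than are shown below. What is called first, only, known or untested is meant among the compounds shown, and "the series" means these compounds.

Going by the values given here, in an ADME assay on the whole organism (Rattus norvegicus, strain Sprague-Dawley) for pharmacokinetics, read by LC-MS, with stated times of 5 min and 24 h, at a dose of 5 mg/kg by the oral route (on this read-out lower numbers stand for lower exposure and higher numbers for higher exposure at the dose given), three compounds have numbers so far. Compound 2 (`COCCNc1cc(NC(=O)N2CCCc3cc(CN4CC[C@H](OC)C4=O)c(C=O)nc32)ncc1C#N`) gives 11300 ng.h/mL there, and compound 3 (`COC[C@@H](C)Nc1cc(NC(=O)N2CCCc3cc(CN4CCCCOC4=O)c(C=O)nc32)ncc1C#N`) gives 9460 ng.h/mL there, so these two stand within the scatter of each other. Compound 1 (`N#Cc1cnc(NC(=O)N2CCCc3cc(CN4CCOCC4=O)c(C=O)nc32)cc1S[C@H]1CCOC1`) gives 1950 ng.h/mL on the same measure, a lower number than compound 2 by a margin beyond the scatter. These three compounds differ in more than one place, so none of their gaps isolates a single structural change.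

Compound 4 (`COCCNc1cc(NC(=O)N2CCCc3cc(CN4CC[C@@H](OC)C4=O)c(C=O)nc32)ncc1C#N`) has the same atoms and bonds as compound 2 (the two compounds have the same atoms and bonds and differ only in configuration as drawn: 1 of 1 stereo elements differ; a stereocentre at a saturated ring carbon is drawn S in compound 2 and R in compound 4), and a stereocentre at a saturated ring carbon is drawn S in compound 2 and R in compound 4. Among the compounds with values here, no two measured compounds differ in configuration alone, so the data give no size for such a change. No step beyond the scatter is therefore expected in this assay in either direction. The expected step (a 1.4-fold lower number from compound 2 to compound 4 (0.15 log units; within the scatter)) lies within the scatter. The expectation starts from compound 2 at 11300 ng.h/mL and leaves a wide margin for what the data cannot size. Compound 4 is estimated at 8000 ng.h/mL with an expected range of 3000 ng.h/mL to 18000 ng.h/mL on this measure.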

Compound 4, area under the concentration-time curve: 12300 ng.h/mL
For compound 4 the middle estimate is 1.5-fold (0.19 log units) below the measured one, within the range that was stated.
By their numbers in this assay, from the lowest: compound 1; then compounds 3, 2 and 4 (each within the scatter of the next).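

In this assay, inverting the stereocentre at the saturated ring carbon from S to R comes to a 1.1-fold higher number from compound 2 to compound 4 (0.04 log units; within the scatter), so on this read-out the two configurations at this position cannot be told apart. Going by these compounds alone, this is the first pair in the set to isolate a single change, since the earlier compounds differ in more than one place and could put no size on a change of configuration; here that size is small enough to lie within the usual scatter of repeated measurements. The result therefore speaks to configuration at this one carbon and to nothing else in the structure: the fact that compounds 2 and 4 differ only in the configuration as drawn

The compounds shown leave open whether the two configurations would stay this close with a different group on the same ring carbon, such as a primary amine or a carboxylic acid in place of the present substituent. They also leave open whether the same holds on other versions of the shared core, such as those carrying the side chains of compound 1 or compound 3, where this ring carbon is not a stereocentre at all.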